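The source may hold more compounds than are shown below. What is called first, only, known or untested is meant among the compounds shown, and "the series" means these compounds.

Series notes: three compounds on a shared core carrying two 2-hydroxyphenyl groups, differing only in the third aromatic substituent.

Among the measured compounds shown here, compound 1 `Oc1ccccc1-c1cc(-c2cccs2)cc(-c2ccccc2O)n1` is the only member with a result. In an assay on isolated protein for inhibition of DNA topoisomerase 1 (Homo sapiens), with a stated time of 30 min, tested at 20 uM (on this read-out higher numbers stand for a stronger effect at the one concentration tested and lower numbers for a weaker effect), compound 1 gives 0.2%, a read-out that is effectively no inhibition at the single concentration tested.

Compound 2 `Oc1ccccc1-c1cc(-c2ccoc2)cc(-c2ccccc2O)n1` was submitted to this assay, where compound 2 is recorded as "not determined" (no result reported), so compound 2 stands without a number and nothing can be said about where it sits relative to compound 1.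

Compound 3 `Oc1ccccc1-c1cc(-c2cccnc2)cc(-c2ccccc2O)n1` is the next member and is still to be measured in this assay. Relative to compound 2 the change is pyridin-3-yl in place of furan-3-yl on an aromatic carbon. For the measured compounds named here, no measured step between any pair exists, so the size of the step from compound 2 to compound 3 in this assay cannot be computed; with compound 1 showing 0.2%, no step beyond the scatter is expected and compound 3 is expected to remain near the bottom of the scale. On that basis compound 3 is estimated to give 5% in this assay, with an expected range from -8% to 22%.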

Compound 3, a percentage reported as inhibition, at one concentration (the size of the read-out at that concentration, not a potency): 0%
For compound 3 the middle estimate is 5 percentage points above the measured one; the range from low to high includes it.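

In this assay, pyridin-3-yl in place of thiophen-2-yl on the aromatic carbon opposite the ring nitrogen gives a number 0.2 percentage points lower from compound 1 to compound 3 (within the scatter) and leaves the read-out at the bottom of the scale. This position now has two measured groups, a five-membered and a six-membered aromatic ring each with one hetero atom, and neither gives a read-out that separates from the other. The step between compound 2 and compound 3 cannot be read, as compound 2 has no reported result, and no independent measurement bears on the absence of a difference between compound 1 and compound 3.

The compounds shown leave open whether any group at this position can raise the read-out from the bottom of the scale, for example an aminomethyl group, a carboxylic acid or a longer alkyl chain, none of which is an aromatic ring like those compared here. They also leave open whether replacing either of the two 2-hydroxyphenyl groups, for example with a 3-hydroxyphenyl or 4-hydroxyphenyl group, would change the read-out.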